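The compounds below may be only part of what the source reports. "The series", "measured", "known", "first", "only" and "open" are said of these compounds alone.

Measured in a functional assay on BGC-823 cells (Homo sapiens) for cytotoxicity, read by MTT assay, with a stated time of 72 h; on this read-out lower numbers stand for stronger inhibition and higher numbers for weaker inhibition:
- Compound 1 `C=C(C)[C@@H]1CC[C@](C)(O)[C@H]1/C=C/C(C)=C/[C@@H]1C[C@@]2([C@H](OC)O1)[C@H](CCCO)/C(=C(\C)C=O)CC[C@]2(C)O`: > 10000 nM
- Compound 2 `C=C(C)[C@H]1CC[C@@](C)(O)[C@@H]1/C=C/C(C)=C/[C@@H]1C[C@@]2([C@H](OC)O1)[C@H](CCCO)/C(=C(/C)C=O)CC[C@]2(C)O`: > 10000 nM
- Compound 3 `C=C(C)[C@H]1CC[C@@](C)(O)[C@@H]1/C=C/C(C)=C/[C@@H]1C[C@@]2([C@H](OC)O1)[C@H](CCCO)/C(=C(\C)C=O)CC[C@]2(C)O`: > 10000 nM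

Each of these three entries is a limit of the assay and not a number. Compound 3 gives > 10000 nM, which is a limit. It therefore shares its place with the other two compounds, at the limit of > 10000 nM in this assay, at which 3 of the 3 values shown sit.

Compound 4 `C=C(C)[C@H]1CC[C@@](C)(O)[C@@H]1/C=C/C(C)=C/[C@@H]1C[C@@]2([C@H](OCC)O1)[C@H](CCCO)/C(=C(\C)C=O)CC[C@]2(C)O` differs from compound 3 at one place: methyl in place of hydrogen on a saturated chain carbon bound to an oxygen on a saturated carbon, methoxy to ethoxy, with methyl in place of hydrogen on a saturated chain carbon bound to an oxygen on a saturated carbon.

The measured steps bear on this only weakly. They are a step that the two limits leave unreadable from compound 1 to compound 3 and a step that the two limits leave unreadable from compound 2 to compound 3, and neither has a readable size. Among the measured compounds shown here, both are changes of configuration alone, as the fact that compounds 1 and 3 differ only in the configuration as drawn and the fact that compounds 2 and 3 differ only in the configuration as drawn state, and no measured step touches the methoxy group. No change of readable size or direction is therefore expected in this assay, and another limit is the likely result.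

The expected step is a step that the limit leaves unreadable from compound 3 to compound 4, with no direction supported by the data. For compound 4 the estimate is 15000 nM, with an expected range of 8000 nM to 40000 nM.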

Compound 4, half-maximal inhibitory concentration: > 10000 nM
Compound 4: a limit, no number; the forecaster's own chance of this, stated with the estimate: 85%; the middle value lies beyond the limit too.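

Compound 3 and compound 4 both stand only as limits in this assay, so the methoxy to ethoxy change between them gives no readable step. The compounds shown leave open whether that change, or any difference in configuration, alters cytotoxicity at all: the limit of > 10000 nM in this assay, at which 4 of the 4 values shown sit.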